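The source may hold more compounds than are shown below. What is called first, only, known or untested is meant among the compounds shown, and "the series" means these compounds.

Compound 1 `CC(=O)N1CCN(c2ccc(Nc3ncc(C#N)c(-c4c[nH]c5ccccc45)n3)cc2)CC1`: 4 nM
Compound 2 `CC(=O)N1CCN(c2ccc(Nc3ncc(C#N)c(-c4cn(C)c5ccccc45)n3)cc2)CC1`: 30 nM

In a functional assay on MV4-11 cells (Homo sapiens) for antiproliferative activity, read by resazurin assay, with a stated time of 72 h (on this read-out higher numbers stand for weaker inhibition of growth and lower numbers for stronger inhibition of growth), compound 1 gives 4 nM, while compound 2 gives 30 nM, the higher of the two numbers, separated from compound 1 by a 7.5-fold higher number from compound 1 to compound 2 (0.88 log units; beyond the scatter). Compound 3 `CC(=O)N1CCN(c2ccc(Nc3ncc(C#N)c(-c4c(C)[nH]c5ccccc45)n3)cc2)CC1` carries 2-methyl-1H-indol-3-yl in place of 1-methyl-1H-indol-3-yl on an aromatic carbon. For the measured compounds named here, only that one measured step bears on the change: compound 2 had lost the hydrogen on the aromatic nitrogen, and compound 3 restores it while keeping a methyl as part of the 2-methyl-1H-indol-3-yl group. Because a 7.5-fold higher number from compound 1 to compound 2 (0.88 log units; beyond the scatter) came with the loss of that hydrogen, compound 3 is expected to show a 3.0-fold lower number from compound 2 to compound 3 (0.48 log units; beyond the scatter), a lower number, though the untested methyl placement keeps the expectation short of a full return. Compound 3 is estimated at 10 nM, with a range from 3 nM to 40 nM.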

Compound 3, concentration for 50% growth inhibition: 390 nM
For compound 3 the middle estimate is 39-fold (1.59 log units) below the measured one; the whole stated range lies below it.
By their numbers in this assay, from the lowest: compound 1; then compound 2; then compound 3.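

In this assay, the return of the hydrogen on the aromatic nitrogen did not bring back growth inhibition (a 13-fold higher number from compound 2 to compound 3 (1.11 log units; beyond the scatter)), so that hydrogen alone does not set the number. Methyl on the aromatic carbon of the 2-methyl-1H-indol-3-yl group goes with a far larger loss (a 98-fold higher number from compound 1 to compound 3 (1.99 log units; beyond the scatter)) than methyl on the aromatic nitrogen (a 7.5-fold higher number from compound 1 to compound 2 (0.88 log units; beyond the scatter)). No evidence is given that explains this difference. The compounds shown leave open whether a fluorine, a chlorine or an ethyl group on that aromatic carbon would give a similarly high number, or whether this is particular to methyl.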